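The compounds below may be only part of what the source reports. "The series", "measured", "known", "first", "only" and "open" are said of these compounds alone.

Measured so far:
compound 1 `COC(=O)/C=C/c1cccc(N(Cc2ccc(/C=C/c3c(C)cc(C)cc3C)cc2)C(=O)NC(C)C)c1` with 431 nM in an assay on isolated protein with Bile acid receptor (Homo sapiens) as the target; on this read-out higher numbers stand for an effect only at larger amounts of compound and lower numbers for an effect already at smaller amounts;
compound 2 `COC(=O)/C=C/c1cccc(N(Cc2ccc(-c3cccc(OC)c3)cc2)C(=O)NC(C)C)c1` with 1370 nM in this assay.

For the measured compounds named here, compound 2 stands at the higher of the two numbers, the only step to it being a 3.2-fold higher number from compound 1 to compound 2 (0.50 log units; beyond the scatter). Compound 3 `COC(=O)/C=C/c1cccc(N(Cc2ccc(-c3ccc(C)cc3)cc2)C(=O)NC(C)C)c1` differs from compound 2 by 4-methylphenyl in place of 3-methoxyphenyl on an aromatic carbon. Going by the values given here, no measured step exchanges one aryl group for another of this kind; the only step known, from compound 1 to compound 2, replaces a larger styryl group and does not bear directly on it. Compound 3 is therefore expected to stay near compound 2, with a 1.1-fold lower number from compound 2 to compound 3 (0.06 log units; within the scatter) not beyond the scatter, and is estimated at 1200 nM (range 400 nM to 4000 nM).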

Compound 3, half-maximal effective concentration: 449 nM
For compound 3 the middle estimate is 2.7-fold (0.43 log units) above the measured one; measured number inside the range.
By their numbers in this assay, from the lowest: compounds 1 and 3 (each within the scatter of the next); then compound 2.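

The exchange of one aryl group for another at this aromatic carbon, para to a large group, matters in this assay: 4-methylphenyl in place of 3-methoxyphenyl gives a 3.1-fold lower number from compound 2 to compound 3 (0.48 log units; beyond the scatter). Putting 4-methylphenyl in place of 2-(2,4,6-trimethylphenyl)ethenyl gives a 1.0-fold higher number from compound 1 to compound 3 (0.02 log units; within the scatter), so the ethenyl-linked group is not required to reach the number of compound 1. No measurement at hand explains the difference between these aryl groups. The compounds shown leave open whether the methyl group, the methoxy group or their place on the ring decides the step, which 3-methylphenyl or 4-methoxyphenyl could separate. As far as these compounds go, how an amine or a carboxylic acid would read here also remains open.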